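Fluoro in place of methyl: compound 3 to compound 4

The source may report more compounds than this note shows. Statements on the series, on what has been measured and on what is new or still open speak of the compounds shown alone.

In a functional assay on RPMI-8226 cells (Homo sapiens) for cytotoxicity, read by MTT assay, with a stated time of 48 h (a lower number here means a stronger inhibitor, a higher number a weaker inhibitor), compound 1 `FC(F)(F)c1cccc(NN=C2C(Cl)=C(Cl)C(Cl)=C2Cl)c1` gives 110 nM. Among the measured compounds shown here, compound 3 `Cc1cccc(NN=C2C(Cl)=C(Cl)C(Cl)=C2Cl)c1` gives 2000 nM, the higher of the two numbers measured so far. Compound 2 `CC(C)(C)NN=C1C(Cl)=C(Cl)C(Cl)=C1Cl` reads > 3000 nM, which is a limit of the assay and not a number.

Compound 4 `Fc1cccc(NN=C2C(Cl)=C(Cl)C(Cl)=C2Cl)c1` carries fluoro in place of methyl on an aromatic carbon. For the measured compounds named here, one measured step bears on this change, the replacement of trifluoromethyl by methyl, which was large and beyond the scatter: an 18-fold higher number from compound 1 to compound 3 (1.26 log units; beyond the scatter). Fluoro is neither of the two groups in that step, so it offers only a loose guide. Based on that step, a move back towards compound 1 is expected in this assay, covering part of the distance. The expected change is a 2.9-fold lower number from compound 3 to compound 4 (0.46 log units; beyond the scatter), towards a lower number and probably just beyond the scatter. For compound 4 the estimated value is 700 nM, with an expected range of 200 nM to 2200 nM.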

Compound 4, half-maximal inhibitory concentration: 500 nM
The estimate for compound 4 lay 1.4-fold (0.15 log units) above the measured number; low and high end bracket the measured number.
By their numbers in this assay, from the lowest: compound 1; then compound 4; then compound 3. At a limit, above all of these: compound 2.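

In this assay, fluoro in place of methyl gives a 4.0-fold lower number from compound 3 to compound 4 (0.60 log units; beyond the scatter), so exchanging one heavy atom for another on this aromatic carbon is enough to move the number beyond the scatter. Fluoro in place of trifluoromethyl gives a 4.5-fold higher number from compound 1 to compound 4 (0.66 log units; beyond the scatter), so fluoro does not match either of the other two groups. The three groups at this one place now give three separate numbers, lowest with trifluoromethyl, then fluoro, then methyl, and the large gap between compound 1 and compound 3 has a point in the middle.

As far as these compounds go, whether a methoxy group, a nitrile or an amine at the same place would fit this order remains open, as does the effect of moving any of these groups elsewhere on the ring. Nothing in the data available bears on why the three groups fall in this order.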